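The compounds below may be only part of what the source reports. "The series", "measured", "known", "first", "only" and "open" are said of these compounds alone.

Measured compounds:
compound 1, `CC(C)[C@@H](C[C@H]1SC(=O)NC1=O)c1ccc(-c2ccc3cccc(F)c3c2)[nH]c1=O`, in a physicochemical assay for solubility, in phosphate buffer, measured as kinetic solubility (a higher number here means a more soluble compound, a lower number a less soluble compound), gives 23900 nM
compound 2, `CC(C)C(c1ccc(-c2ccc3cccc(F)c3c2)[nH]c1=O)C1C(=O)NC(=O)N1C`, in this assay gives 17900 nM

Compound 2 stands at the lower of the two numbers, with compound 1 the nearest; the gap between them is within the scatter, so the two read as alike in this assay. Among the measured compounds shown here, no pair differing in one place has been measured, so no step size is known for this series.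

Compound 3, `CC(C)C(CC1NC(=O)NC1=O)c1ccc(-c2ccc3cccc(F)c3c2)[nH]c1=O`, is the next compound to be measured. Its change from compound 2 is (2,5-dioxoimidazolidin-4-yl)methyl in place of 3-methyl-2,5-dioxoimidazolidin-4-yl on a saturated chain carbon bound to an aromatic carbon and a saturated chain carbon. The two share the same atoms, joined differently. For the measured compounds named here, with the only comparison within the scatter, no step beyond the scatter is expected in this assay: a 1.2-fold higher number from compound 2 to compound 3 (0.09 log units; within the scatter) is taken as the expected step, close to none. For compound 3 the expected value in this assay is 22000 nM, with a range from 10000 nM to 45000 nM.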

Compound 3, solubility: 12300 nM
The estimate for compound 3 lay 1.8-fold (0.25 log units) above the measured number; low and high end bracket the measured number.
By their numbers in this assay, from the lowest: compounds 3, 2 and 1 (each within the scatter of the next).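

In this assay, the (2,5-dioxoimidazolidin-4-yl)methyl group in place of 3-methyl-2,5-dioxoimidazolidin-4-yl on the saturated chain carbon gives the first step read in this series (a 1.5-fold lower number from compound 2 to compound 3 (0.16 log units; within the scatter)). This step stays within the scatter, so compound 2 and compound 3 read as alike, even though the same atoms are joined differently and the entering group carries 2 hydrogen-bond donors against 1 in the group it replaces. No measurement shown gives a reason for this result.

The compounds shown give no step beyond the scatter at this position, so its sensitivity to change remains unknown. Also open, going by these compounds, is whether a carboxylic acid or an amine on this chain, or a longer chain carrying the ring, would give a step beyond the scatter.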